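Shrinking the acyl group on the shared core

This account rests on a few compounds, and the source may have more. Where it says the series, first, only, none or still open, it means among the compounds named here.

Three compounds of the series have been examined in an assay on HEK293 cells for positive allosteric modulation of metabotropic glutamate receptor 5 (Homo sapiens), read by FLIPR; a lower number here means that less compound is needed, a higher number that more compound is needed for the effect. Compound 1 `Cc1cccc(-c2noc(C3CN(S(=O)(=O)c4ccc(Cl)cc4)C3)n2)c1` returns only a limit, > 10000 nM. Compound 2 `O=C(c1ccccc1F)N1CC[C@H]1c1nc(-c2cccc(F)c2)no1` likewise returns only a limit, > 10000 nM. Going by the values given here, compound 3 `O=C(C1CCC2(CCC2)CC1)N1CC(c2nc(-c3cccc(Cl)c3)no2)C1` gives 1100 nM, the one real number in the set. Among the compounds with values here, the other two values sit at the limit of > 10000 nM in this assay, at which 2 of the 3 values shown sit, and compound 3 therefore stands as the sole point of reference; no step between measured compounds can be read.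

Compound 4 `O=C(C1CCC1)N1CC(c2nc(-c3cccc(Cl)c3)no2)C1` follows from compound 3 by a single change: a group of 4 heavy atoms (4 carbon; one four-membered non-aromatic ring of carbon only) in place of a group of 9 heavy atoms (9 carbon; one four-membered non-aromatic ring of carbon only, one six-membered non-aromatic ring of carbon only), on a carbonyl carbon. The amide-type nitrogen in a ring, the carbonyl and the remainder of the shared core are kept. Within the data shown here, nothing among the measured compounds shows what altering the carbon framework on the carbonyl carbon does, and the expectation rests on compound 3 alone. The expected change, a 3.6-fold higher number from compound 3 to compound 4 (0.56 log units; beyond the scatter), is a step toward a higher number in this assay, estimated to lie beyond the usual scatter. Compound 4 is accordingly expected to give 4000 nM, within 1500 nM to 15000 nM, with a real chance that this assay returns only a limit.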

Compound 4, half-maximal effective concentration: > 10000 nM
Compound 4 ended at the assay's limit; the forecaster's own chance of this, stated with the estimate: 35%; at least 2.5-fold (0.39 log units) between middle value and limit.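

The series now has its first readable step at this position, on a carbonyl carbon whose other neighbour is the amide-type nitrogen in a ring: cyclobutyl in place of the larger group holding a four-membered and a six-membered ring gives an at least 9.0-fold higher number from compound 3 to compound 4 (0.95 log units; beyond the scatter). With the shared core kept, the measurable response of compound 3 in this assay therefore depends on what sits on this carbonyl carbon, and cyclobutyl alone does not retain it. Compound 4 returns only a limit, so the step gives a lower bound on the change, and nearly the whole set now stands at that ceiling: the limit of > 10000 nM in this assay, at which 3 of the 4 values shown sit.

Going by these compounds, it remains open whether the response follows the size of the group or the arrangement of its rings; a cyclohexyl group or a longer alkyl chain on the same carbonyl carbon would help separate the two. The steps involving compound 1 and compound 2 cannot be read, so the contributions of the other parts of the structure also remain unresolved.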